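The source may report more compounds than this note shows. Statements on the series, on what has been measured and on what is new or still open speak of the compounds shown alone.

Measured compounds:
- compound 1 `CS/C(=N\C(=O)c1csc([N+](=O)[O-])c1)NC(=O)c1csc([N+](=O)[O-])c1` — in a functional assay on HepG2 cells (Homo sapiens) for cytotoxicity, read by MTT assay, with a stated time of 72 h (on this read-out lower numbers stand for stronger inhibition of growth and higher numbers for weaker inhibition of growth), compound 1 is reported at the limit > 100000 nM
- compound 2 `C[Se]/C(=N\C(=O)c1sccc1Cl)NC(=O)c1sccc1Cl` — in this assay compound 2 gives 4020 nM

Compound 1 is placed only by a limit of the assay, not by a number (the limit of > 100000 nM in this assay, at which 1 of the 2 values shown sits); in this assay compound 1 therefore stands at the weak end of what is shown, and nothing more can be said of where inside that region it lies. Among the compounds with values here, compound 2 differs from compound 1 in more than one place, so its value shows only that a related selenium-bearing compound reaches a measurable concentration for total growth inhibition.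

Compound 3 `C[Se]/C(=N\C(=O)c1csc([N+](=O)[O-])c1)NC(=O)c1csc([N+](=O)[O-])c1` has not yet been measured in this assay. It differs from compound 1 by a group of 2 heavy atoms (1 carbon, 1 selenium; no ring) in place of a group of 2 heavy atoms (1 carbon, 1 sulfur; no ring), on a carbon with a double bond to nitrogen. Within the data shown here, no step between two measured compounds isolates this change. Starting from a limit, the step from compound 1 to compound 3 is expected to run toward stronger inhibition of growth, with an expected size of an at least 2.5-fold lower number from compound 1 to compound 3 (0.39 log units; beyond the scatter), though its size is uncertain. For compound 3 the expected value in this assay is 40000 nM, within a range of 8000 nM to 150000 nM.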

Compound 3, concentration for total growth inhibition: 1550 nM
Beside the measured number, compound 3's estimate is 26-fold (1.41 log units) above it; measured number outside the range, below it.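

In this assay, exchanging methylsulfanyl for the group of carbon and selenium, on a carbon with a double bond to nitrogen whose other neighbours are amide-type nitrogens, gives an at least 64-fold lower number from compound 1 to compound 3 (1.80 log units; beyond the scatter). This is the first pair shown that isolates the change, and with the rest of the core of compound 1 held fixed, replacing sulfur with selenium alone is enough to give a measurable concentration for total growth inhibition. The size of the step is a floor rather than a measure, and compound 1 is placed only by a limit of the assay: the limit of > 100000 nM in this assay, at which 1 of the 3 values shown sits.

Going by these compounds, whether the same exchange has a similar effect on the core of compound 2 remains open. Also open, on these data alone, is how a longer chain on the selenium, such as ethyl, or an amine on this carbon would compare in this assay.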